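Oleyl to linolenyl ester: an expected step

A few compounds are considered here, and "the series" means these few. Any claim that something is new, unique, unknown or untested is made for them only; others in the source may bear on it.

Measured compounds:
- compound 1, `CCCCCCCC/C=C\CCCCCCCC(=O)OCC1CCCCO1`: 35%
- compound 2, `O=C(OCC1CO1)c1ccccc1`: 0.2%
- compound 3, `CCCCC/C=C\C/C=C\C/C=C\C/C=C\CCCC(=O)OC[C@H]1COC(C)(C)O1`: 34%

Three esters were tested in an assay on membranes from cerebellum for inhibition of Monoglyceride lipase (Rattus norvegicus), tested at 100 uM; on this read-out lower numbers stand for less inhibition and higher numbers for more inhibition at the one concentration tested (going by the name of the read-out). Compound 1 gives 35%, the highest of the three numbers. Compound 3 gives 34%, a number within the scatter of compound 1, so no order between these two can be claimed. Compound 2 gives 0.2%, a number that lies far beyond the scatter below compound 1.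

The account now turns from compound 1 to the unmeasured compound 4, `CC/C=C\C/C=C\C/C=C\CCCCCCCC(=O)OCC1CCCCO1`. The two differ in one place: hepta-1,4-dien-1-yl in place of heptyl on a saturated chain carbon bound to a double-bonded chain carbon. The acyl chain keeps its length and the ester head is unchanged; only the saturation of the chain end shifts.

Among the compounds with values here, no measured pair shows this exact change. Compound 3, with a chain carrying several double bonds, gives a number within the scatter of compound 1, so a shift beyond the scatter is not expected in this assay. The step of a number 3 percentage points higher from compound 1 to compound 4 (within the scatter) is expected to stay within the usual scatter. Compound 4 is therefore estimated at 38%, with a range from 22% to 55%.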

Compound 4, a percentage reported as inhibition, at one concentration (the size of the read-out at that concentration, not a potency): 33%
For compound 4 the middle estimate is 5 percentage points above the measured one; low and high end bracket the measured number.
By their numbers in this assay, from the lowest: compound 2; then compounds 4, 3 and 1 (each within the scatter of the next).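

In this assay the step to the unsaturated chain end amounts to a number 2 percentage points lower from compound 1 to compound 4 (within the scatter) and so gives no readable change: at this place on the chain, hepta-1,4-dien-1-yl can stand in for heptyl with the number staying where it was. The earlier compounds shown here could not show this, since compound 3 differs from compound 1 in more than one place, whereas here the ester head and the chain length are held fixed and only the chain end changes. Nothing available here says why the number holds.

Still open, going by these compounds, is whether a longer chain, or an amine or a carboxylic acid at the chain end, would shift the number beyond the scatter. Also open, on these data alone, is whether a chain end with only one of the two added double bonds would behave in the same way.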